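A few compounds are considered here, and "the series" means these few. Any claim that something is new, unique, unknown or untested is made for them only; others in the source may bear on it.

Compound 1 `Cc1ccc(S(=O)(=O)N[C@@H](CC(=O)NC(C)(C)C)C(=O)NCCNC(=O)c2ccc(F)cc2)cc1`: in an ADME assay on HepG2 cells (Homo sapiens) for cytotoxicity (a higher number here means that more compound is needed for the effect, a lower number that less compound is needed), compound 1 gives > 11000 nM, which is a limit of the assay and not a number.
Compound 2 `Cc1ccc(S(=O)(=O)N[C@@H](CC(=O)NC(C)(C)C)C(=O)NCCNC(=O)c2ccc(Cl)cc2)cc1`: in this assay compound 2 gives > 11000 nM, again a limit.
Compound 3 `Cc1ccc(S(=O)(=O)N[C@@H](CC(=O)NC(C)(C)C)C(=O)NCCNC(=O)c2cc(C)ccn2)cc1`: in this assay compound 3 gives > 11000 nM, again a limit.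

Compound 1 therefore stands at the limit of > 11000 nM in this assay, at which 3 of the 3 values shown sit; none of the three compounds has a value that separates it from the others. The comparisons that can be formed are all of the same kind: a step that the two limits leave unreadable from compound 1 to compound 2, a step that the two limits leave unreadable from compound 1 to compound 3 and a step that the two limits leave unreadable from compound 2 to compound 3. None of them can be given a size.

The compound now in question is compound 4 `Cc1ccc(S(=O)(=O)N[C@@H](CC(=O)NC(C)(C)C)C(=O)NCCNC(=O)c2ccccn2)cc1`. Relative to compound 1 the change is pyridin-2-yl in place of 4-fluorophenyl on a carbonyl carbon. The changes from compound 1 to compound 3 and from compound 2 to compound 3 are the nearest in kind, since a pyridinyl group enters there as well, but both of those steps are unreadable, and the change from compound 1 to compound 2 is unreadable too. For the measured compounds named here, there is thus no measured step from which a direction or size could be taken, and no value in the set that a pyridinyl-bearing compound has moved off the limit.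

Compound 4 is accordingly expected to give about 20000 nM in this assay, within 8000 nM to 60000 nM, most likely again reported only as a limit. The step this estimate implies is a step that the limit leaves unreadable from compound 1 to compound 4, expected to be no more than what the scatter allows.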

Compound 4, half-maximal effective concentration: > 11000 nM
Compound 4 gave a limit, no number; the forecaster's own chance of this, stated with the estimate: 85%; the middle value is on the limit's open side.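

No new step can be read: compound 4 also gives only a limit in this assay, so its steps from compound 1, compound 2 and compound 3 cannot be sized, and all four compounds stand together: the limit of > 11000 nM in this assay, at which 4 of the 4 values shown sit. The compounds shown leave open whether exchanging the group on the carbonyl carbon changes the value in this assay at all.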